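A few compounds are considered here, and "the series" means these few. Any claim that something is new, unique, unknown or untested is made for them only; others in the source may bear on it.

Compound 1 `O=S(=O)(Nc1cccc(CO)c1)c1ccc(-c2ccc(Br)cc2)cc1` is the reference point of this set. For the measured compounds named here, in a functional assay on J774 cells (Mus musculus) for cytotoxicity, read by resazurin assay, with a stated time of 72 h (a higher number here means a weaker inhibitor, a lower number a stronger inhibitor), compound 1 gives 2500 nM, and this is the only outright number among the three values shown. Compound 2 and compound 3 each stand at a limit of the assay (the limit of > 5000 nM in this assay, at which 2 of the 3 values shown sit). Compound 2 `CN(C)c1ccc(-c2ccc(S(=O)(=O)Nc3cccc(CO)c3)cc2)cc1` carries a dimethylamino group in place of the bromo group on an aromatic carbon. In this assay compound 2 reaches only the limit of > 5000 nM, so no number is known for it. Compound 3 `Cc1ccc(CO)cc1NS(=O)(=O)c1ccc(-c2ccc(Br)cc2)cc1` carries a methyl group in place of a hydrogen on an aromatic carbon of the ring that bears the hydroxymethyl group. In this assay compound 3 likewise sits at the limit of > 5000 nM. The two steps from compound 1 are therefore an at least 2.0-fold higher number from compound 1 to compound 2 (0.30 log units; that floor lies within the scatter) and an at least 2.0-fold higher number from compound 1 to compound 3 (0.30 log units; that floor lies within the scatter), each a floor rather than a measured size.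

Compound 4 `O=S(=O)(Nc1cccc(CO)c1Cl)c1ccc(-c2ccc(Br)cc2)cc1` differs from compound 1 by chloro in place of hydrogen on an aromatic carbon. Going by the values given here, the step that bears most directly on it is the one to compound 3, where a small group also entered the same ring of compound 1 and the value moved beyond the limit. A higher number in this assay is thus expected for compound 4, quite possibly again only a limit. Compound 4 is estimated to give 5000 nM, with a range from 2000 nM to 12000 nM. That corresponds to an expected step of a 2.0-fold higher number from compound 1 to compound 4 (0.30 log units; within the scatter).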

Compound 4, half-maximal inhibitory concentration: 5000 nM
Estimate against measurement, compound 4: no gap at the digits printed; the range from low to high includes it.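

Chloro ortho to a hydroxymethyl group gives the first step in this set whose size is measured and is not just a floor: in this assay, the change is a 2.0-fold higher number from compound 1 to compound 4 (0.30 log units; within the scatter). Since that step lies within the usual scatter, the data cannot separate the chloro of compound 4 from the hydrogen of compound 1 at this position, and a single added chlorine atom on this ring is thus compatible with an unchanged reading in these cells. Compound 4 does have an outright number, but that number falls on the same figure at which the assay stops giving numbers, so little room remains above it for reading any further change: the limit of > 5000 nM in this assay, at which 2 of the 4 values shown sit.

Among the compounds shown, chloro is the only group at this position, so it remains open whether a fluoro, a methoxy, an amine or a carboxylic acid there would also stay within the scatter of compound 1. As far as these compounds go, it is equally open how the reading would respond to a longer chain in place of the hydroxymethyl group, with the chloro kept where it is.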